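Chloro-to-fluoro swap on the benzylsulfanyl arm, second instance

The source may report more compounds than this note shows. Statements on the series, on what has been measured and on what is new or still open speak of the compounds shown alone.

Working notes on a small set of dihydropyrimidine carboxamides tested in a functional assay on the whole organism (artery, strain albino) with Rattus norvegicus as the target, with a stated time of 600 min, at a dose of 10 mg/kg by the oral route; a higher number here means more inhibition at the dose given (going by the name of the read-out), a lower number less inhibition.

Compound 1 `CC1=C(C(=O)Nc2ccc(F)cc2)C(c2ccc([N+](=O)[O-])cc2)N=C(SCc2ccc(Cl)cc2)N1` gives 28.2%. Compound 2 `CC1=C(C(=O)Nc2ccc(F)cc2)C(c2ccc([N+](=O)[O-])cc2)N=C(SCc2ccc(F)cc2)N1` gives 25.6%. The change between them, (fluoro in place of chloro on an aromatic carbon), produced a number 2.6 percentage points lower from compound 1 to compound 2 (within the scatter), so the two numbers cannot be told apart by this measurement.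

Compound 3 `CC1=C(C(=O)Nc2ccc([N+](=O)[O-])cc2)C(c2ccc(Br)cc2)N=C(SCc2ccc(Cl)cc2)N1` gives 34.4%. Its core differs from that of compound 1 in more than one place, and the difference between the two cores is not broken down here; the values of compound 3 and compound 1 lie within the scatter of each other, as do those of compound 3 and compound 2.

Compound 4 `CC1=C(C(=O)Nc2ccc([N+](=O)[O-])cc2)C(c2ccc(Br)cc2)N=C(SCc2ccc(F)cc2)N1` has not been measured. It stands to compound 3 as compound 2 stands to compound 1: fluoro in place of chloro on an aromatic carbon, at a place described in identical words for both pairs, so this is the same change made a second time. Going by the values given here, with only one earlier instance, the expectation rests on that one step: because compound 1 to compound 2 showed a number 2.6 percentage points lower from compound 1 to compound 2 (within the scatter), the step from compound 3 to compound 4 is estimated at a number 2.4 percentage points lower from compound 3 to compound 4 (within the scatter), again within the scatter. Compound 4 is accordingly expected to give about 32% in this assay, most likely between 22% and 42%.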

Compound 4, a percentage reported as inhibition, in the whole organism at one dose (the size of the read-out at that dose, not a potency): 32.3%
For compound 4 the middle estimate is 0.3 percentage points below the measured one, and the stated range covers the measured number.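

In this assay, the swap of (4-chlorobenzyl)sulfanyl to (4-fluorobenzyl)sulfanyl on the core of compound 3 gives a number 2.1 percentage points lower from compound 3 to compound 4 (within the scatter), and set beside the earlier instance the two steps agree: the same change on two cores in this assay, a number 2.6 percentage points lower (within the scatter) from compound 1 to compound 2 and a number 2.1 percentage points lower (within the scatter) from compound 3 to compound 4, 0.5 percentage points apart, within the scatter of two such steps. On these two cores, then, the change carries over in the plain sense that neither step can be told from the scatter, so chloro and fluoro at this place are interchangeable as far as this measurement can see. This does not show that the change has a fixed effect of a defined size, since two steps this small agree as much through lying within the scatter as through any shared effect, and it says nothing about other cores, other doses or other times.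

The compounds shown carry only chloro or fluoro at this place on the benzyl ring, so it stays open whether a methoxy group, a nitrile or a carboxylic acid there, or a plain alkyl chain in place of the whole benzyl group, would give a step beyond the scatter. Also open, from the compounds shown here alone, is what each single difference between the core of compound 1 and the core of compound 3 contributes on its own.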